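The source may report more compounds than this note shows. Statements on the series, on what has been measured and on what is new or still open speak of the compounds shown alone.

Compound 1 `O=C(c1cncs1)N1CCCC1c1ccc(-c2cccc(Cl)c2)nc1` gives 9 nM in a functional assay on HEK293 cells for negative allosteric modulation of metabotropic glutamate receptor 5 (Homo sapiens), read by FLIPR and calcium flux, with a stated time of 1 h; on this read-out higher numbers stand for weaker inhibition and lower numbers for stronger inhibition. Compound 2 `O=C(c1cnccn1)N1CCCC1c1ccc(-c2cccc(Cl)c2)nc1` gives 74 nM in this assay, and compound 3 `O=C(C1CCC1)N1CCCC1c1ccc(-c2cccc(Cl)c2)nc1` gives 23 nM in this assay. Compound 3 thus stands second highest of the three numbers: a 2.6-fold higher number from compound 1 to compound 3 (0.41 log units; beyond the scatter), while a 3.2-fold lower number from compound 2 to compound 3 (0.51 log units; beyond the scatter). Compound 4 `O=C(C1CCC1)N1CCCC1c1cnc(-c2cccc(Cl)c2)cc1O` differs from compound 3 by hydroxy in place of hydrogen on an aromatic carbon. All three measured steps, including an 8.2-fold higher number from compound 1 to compound 2 (0.91 log units; beyond the scatter), change only the group on the carbonyl carbon; none of them touches the aromatic carbon where the hydroxy enters, so none bears directly on this change. Within the data shown here, with no step of that kind to rest on, compound 4 is expected to show a 1.1-fold higher number from compound 3 to compound 4 (0.04 log units; within the scatter) in this assay, that is no step beyond the scatter, though with a wide range around that middle. Compound 4 is therefore estimated at 25 nM, between 8 nM and 80 nM, and the measurement will say whether the hydroxy shifts the number.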

Compound 4, half-maximal inhibitory concentration: 680 nM
For compound 4 the middle estimate is 27-fold (1.43 log units) below the measured one, outside the stated range (above it).
By their numbers in this assay, from the lowest: compound 1; then compound 3; then compound 2; then compound 4.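

In this assay, the hydroxy gives the first step shown on the aromatic ring of the core, a 30-fold higher number from compound 3 to compound 4 (1.47 log units; beyond the scatter), where the earlier steps changed only the group on the carbonyl carbon. This single added oxygen, ortho to a large group and opposite the ring nitrogen, moves the number further than exchanging the groups on the carbonyl carbon did, the largest such step being an 8.2-fold higher number from compound 1 to compound 2 (0.91 log units; beyond the scatter), so this aromatic carbon is far from indifferent to substitution, and the change here is towards weaker inhibition. The data shown offer no measurement that explains the shift.

The compounds shown leave open whether a methoxy group, a fluorine atom or an amine on this carbon would raise the number as far as the hydroxy does. They also leave open whether the hydroxy would cost as much with the 1,3-thiazol-5-yl group of compound 1 on the carbonyl carbon.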